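The source may hold more compounds than are shown below. What is called first, only, known or untested is meant among the compounds shown, and "the series" means these compounds.

Compound 1 `O=c1cc(Nc2ccccc2)cc(-c2ccccc2)o1` is one of two compounds for which a number exists in a functional assay on SK-BR-3 cells (Homo sapiens) for cytotoxicity, read by MTT assay, with a stated time of 72 h; on this read-out higher numbers stand for an effect only at larger amounts of compound and lower numbers for an effect already at smaller amounts. In this assay, among the compounds with values here, compound 1 gives 0.13 uM, which stands at the upper end of the two numbers; the only neighbour is compound 2 `Cc1ccc(Nc2cc(-c3ccccc3)oc(=O)c2)cc1`, which in this assay gives 0.09 uM. The step between them is a 1.4-fold lower number from compound 1 to compound 2 (0.16 log units; within the scatter). The two compounds differ by methyl in place of hydrogen on an aromatic carbon, and they cannot be told apart on this read-out.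

Compound 3 `COc1ccccc1Nc1cc(-c2ccccc2)oc(=O)c1` has not yet been measured. It differs from compound 1 by methoxy in place of hydrogen on an aromatic carbon. Within the data shown here, one measured step bears on this change, namely the one from compound 1 to compound 2, since it too puts a small group in place of a hydrogen on an aromatic carbon, and that step was a 1.4-fold lower number from compound 1 to compound 2 (0.16 log units; within the scatter). On this basis no step beyond the scatter is expected in this assay, in either direction. The step from compound 1 to compound 3 is estimated at a 1.1-fold higher number from compound 1 to compound 3 (0.03 log units; within the scatter). For compound 3 the expected value in this assay is therefore 0.14 uM, within a range from 0.05 uM to 0.45 uM.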

Compound 3, concentration for half-maximal effect: 0.54 uM
For compound 3 the middle estimate is 3.9-fold (0.59 log units) below the measured one; the whole stated range lies below it.
By their numbers in this assay, from the lowest: compounds 2 and 1 (each within the scatter of the next); then compound 3.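

In this assay, within the data shown here, methoxy in place of hydrogen on an aromatic carbon, ortho to a large group, gives a 4.2-fold higher number from compound 1 to compound 3 (0.62 log units; beyond the scatter) and is the first change on this six-membered aromatic ring of carbon only to move the number beyond the scatter. The earlier step, a 1.4-fold lower number from compound 1 to compound 2 (0.16 log units; within the scatter), stayed within the scatter, so the ring does not treat every small replacement for hydrogen alike, although that step differs from the new one in both the group and its place on the ring. No measured property of these compounds is available to account for the new step.

Whether the higher number belongs to methoxy itself or to any group placed ortho to a large group remains open, since the compounds shown include neither a hydroxy group, a fluorine atom nor an amine at this place, and no methoxy at another place on the ring. As far as these compounds go, it is also open how a longer chain on the same oxygen, such as ethoxy, would compare with the methoxy of compound 3.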